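A few compounds are considered here, and "the series" means these few. Any claim that something is new, unique, unknown or untested is made for them only; others in the source may bear on it.

Working notes on the series. Compound 1 `Cc1cccc(-c2nc3cc(C)ccc3c(=O)[nH]2)c1` and compound 2 `Cc1cccc(-c2nc3ccc(C)cc3c(=O)[nH]2)c1` are built from the same atoms joined differently; the difference between the two cores is not broken down here. Compound 3 `Cc1ccc2nc(-c3cccc(F)c3)[nH]c(=O)c2c1` shares the core of compound 2, and compound 4 `Cc1ccc2c(=O)[nH]c(-c3cccc(F)c3)nc2c1` shares the core of compound 1. In an assay on isolated protein for inhibition of DNA topoisomerase 1 (Homo sapiens), with a stated time of 30 min, tested at 100 uM (a higher number here means a stronger effect of the compound at the concentration tested, a lower number a weaker effect), compound 1 gives 100%, the highest of the three measured numbers, with every other compound beyond the scatter below it. In this assay compound 2 gives 75.7%, and compound 3 gives 82.9%. The change from compound 2 to compound 3 is fluoro in place of methyl on an aromatic carbon and moves the read-out by a number 7.2 percentage points higher from compound 2 to compound 3 (within the scatter), a step within the scatter. The same change, at the same place, turns compound 1 into compound 4: fluoro in place of methyl on an aromatic carbon. Among these compounds it occurs twice in all. The step expected in this assay is a number 4 percentage points lower from compound 1 to compound 4 (within the scatter), close to the earlier one, because a number 7.2 percentage points higher from compound 2 to compound 3 (within the scatter) was small and compound 1 already stands at the top of the read-out. For compound 4 in this assay the expected value is 96%, estimated to fall between 85% and 100%.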

Compound 4, a percentage reported as inhibition, at one concentration (the size of the read-out at that concentration, not a potency): 77.5%
Compound 4: the middle estimate sits 18.5 percentage points above what was measured; the measured number lies below the stated range.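

Fluoro in place of methyl on an aromatic carbon gives a number 22.5 percentage points lower from compound 1 to compound 4 (beyond the scatter) in this assay. Among these compounds, the outcome of this change therefore differs between the two cores, and the step seen on one core cannot be carried over to the other as a fixed increment: the same change on two cores in this assay, a number 7.2 percentage points higher (within the scatter) from compound 2 to compound 3 and a number 22.5 percentage points lower (beyond the scatter) from compound 1 to compound 4, 29.7 percentage points apart, beyond the scatter of two such steps This rests on only two matched pairs, each read at a single concentration, with compound 1 at 100%, so it shows neither why the cores differ nor whether potency follows the same course.

The compounds shown leave open how the two cores respond at this place to groups other than methyl and fluoro, such as an amine, a methoxy group or a carboxylic acid. They also leave open whether the same divergence appears when the methyl on the core itself gives way to a longer chain such as propyl.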